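Removing One Methoxy Group: Expected Cytotoxicity of Compound 4

The compounds below may be only part of what the source reports. "The series", "measured", "known", "first", "only" and "open" are said of these compounds alone.

Measured compounds:
Compound 1 `COc1ccc(-c2cc(/C=C/C(=O)c3ccc(N)cc3)[nH]n2)cc1`: -73%
Compound 2 `COc1cc(-c2cc(/C=C/C(=O)c3ccc(N)cc3)[nH]n2)cc(OC)c1OC`: -63%
Compound 3 `COc1ccc(C(=O)/C=C/c2cc(-c3cc(OC)c(OC)c(OC)c3)n[nH]2)cc1`: -93%

In a functional assay on ACHN cells (Homo sapiens) for cytotoxicity, read by sulforhodamine B assay, with a stated time of 48 h, tested at 100 uM (a lower number here means a stronger effect, a higher number a weaker effect of the compound at the concentration tested), compound 2 gives -63%, the highest of the three numbers; compound 1 lies within the scatter of it, while compound 3 sits further off. Going by the values given here, the only single-point step known runs a number 30 percentage points lower from compound 2 to compound 3 (beyond the scatter), and it swaps a different group. Compound 4 `COc1ccc(-c2cc(/C=C/C(=O)c3ccc(N)cc3)[nH]n2)cc1OC` differs from compound 2 by hydrogen in place of methoxy on an aromatic carbon. Among the compounds with values here, no measured step removes a methoxy group, so the step is expected to stay within the scatter, estimated as a number 5 percentage points lower from compound 2 to compound 4 (within the scatter). Compound 4 is therefore expected to give -68% in this assay, between -90% and -45%.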

Compound 4, a percentage reported as activity, at one concentration (the size of the read-out at that concentration, not a potency): -95%
Compound 4: the middle estimate sits 27 percentage points above what was measured; measured number outside the range, below it.
By their numbers in this assay, from the lowest: compounds 4 and 3 (each within the scatter of the next); then compounds 1 and 2 (each within the scatter of the next).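

In this assay, the methoxy group on this aromatic carbon proves to matter: removing one gives a number 32 percentage points lower from compound 2 to compound 4 (beyond the scatter), while adding one gives a number 22 percentage points lower from compound 1 to compound 4 (beyond the scatter). Both steps end at compound 4, so the number does not simply follow how many methoxy groups this ring carries, since compound 1 and compound 2, which flank compound 4 in that respect, stay within the scatter of each other. The effect of a methoxy group here therefore depends on what else the ring holds.

No measurement shown explains this result. As far as these compounds go, whether a hydroxy group or a fluorine atom on this carbon would give a number like that of compound 4 remains open.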